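Swapping the acid for a triazole on the ether arm

A few compounds are considered here, and "the series" means these few. Any claim that something is new, unique, unknown or untested is made for them only; others in the source may bear on it.

Measured compounds:
compound 1 `c1ccc(-c2nnn[nH]2)c(-c2ccc(CCc3nc(CC4CCCC4)c[nH]3)cc2)c1` gives 56 nM
compound 2 `CCC(C)(C)Cc1c[nH]c(CCc2ccc(-c3ccccc3O)cc2)n1` gives 133 nM
compound 3 `CCC(C)(C)Cc1c[nH]c(CCc2ccc(-c3ccccc3OCC(=O)O)cc2)n1` gives 54 nM

In a functional assay for agonist activity at Bombesin receptor subtype-3 (Homo sapiens) (a higher number here means that more compound is needed for the effect, a lower number that less compound is needed), compound 3 stands at the low end of the three numbers. Going by the values given here, compound 1 sits within the scatter of compound 3, so no order can be read between them, while compound 2 needs clearly more: the only single-point step in this set, a 2.5-fold lower number from compound 2 to compound 3 (0.39 log units; beyond the scatter), shows that carboxymethyl in place of hydrogen on the ring oxygen brings a modest gain.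

Compound 4 `CCC(C)(C)Cc1c[nH]c(CCc2ccc(-c3ccccc3OCc3ncn[nH]3)cc2)n1` keeps everything in compound 3 except the end of that ether arm: 1H-1,2,4-triazol-5-yl in place of carboxy on a saturated chain carbon bound to an oxygen on an aromatic ring. Among the compounds with values here, no measured step covers this exact exchange. The step from compound 2 to compound 3 shows only that something larger than hydrogen at this oxygen helps; compound 1, which differs from compound 3 in several places, carries its own aromatic ring with hetero atoms and gives a number within the scatter of compound 3. The expectation is therefore a step of about a 1.3-fold higher number from compound 3 to compound 4 (0.11 log units; within the scatter), that is, no change beyond the scatter, with a modest loss as the more likely direction if one occurs. Compound 4 is estimated at 70 nM, in the range 25 nM to 200 nM.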

Compound 4, half-maximal effective concentration: 172 nM
Beside the measured number, compound 4's estimate is 2.5-fold (0.39 log units) below it; low and high end bracket the measured number.
By their numbers in this assay, from the lowest: compounds 3 and 1 (each within the scatter of the next); then compounds 2 and 4 (each within the scatter of the next).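

In this assay the end of the ether arm turns out to matter: 1H-1,2,4-triazol-5-yl in place of carboxy gives a 3.2-fold higher number from compound 3 to compound 4 (0.50 log units; beyond the scatter) and so does not keep the gain that the carboxymethyl arm brought to the ring oxygen. Measured against the bare oxygen, (1H-1,2,4-triazol-5-yl)methyl in place of hydrogen gives a 1.3-fold higher number from compound 2 to compound 4 (0.11 log units; within the scatter) and so cannot be told apart from hydrogen at this position, which means that simply placing something larger than hydrogen on this oxygen is not enough in these compounds. Nothing measured here accounts for the difference between the two end groups.

Still open, on these data alone, is whether a primary amide or a sulfonic acid at the end of the arm, or a longer chain carrying the carboxy group, would match compound 3 or improve on it. Also open, as far as these compounds go, is whether the exchange of carboxy for the triazole would give a similar step with a different group on the other side of the shared core.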